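Propargyl to Benzyl on Carbamate Amines Against Amine Oxidase B

The source may hold more compounds than are shown below. What is called first, only, known or untested is meant among the compounds shown, and "the series" means these compounds.

Three compounds are measured in an assay on BTI-TN-5B1-4 cells for inhibition of Amine oxidase [flavin-containing] B (Homo sapiens), read by fluorescence and Amplex Red, using microsomes, with a stated time of 15 min; on this read-out higher numbers stand for weaker inhibition and lower numbers for stronger inhibition:
Compound 1 `C#CCN1CCCC(OC(=O)Nc2ccccc2)C1` gives > 100000 nM, which is a limit of the assay rather than a number.
Compound 2 `O=C(Nc1ccccc1)OC1CCCN(Cc2ccccc2)C1` gives 33300 nM.
Compound 3 `C#CCN1CCC(COC(=O)N(C)CC)CC1` gives > 100000 nM, again a limit of the assay.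

Compound 1 and compound 2 differ by phenyl in place of ethynyl on a saturated chain carbon bound to an amine nitrogen in a ring. This change produced an at least 3.0-fold lower number from compound 1 to compound 2 (0.47 log units; beyond the scatter), and its size is known only as a bound because two of the three values sit at the limit of > 100000 nM in this assay, at which 2 of the 3 values shown sit.

Compound 4 `CCN(C)C(=O)OCC1CCN(Cc2ccccc2)CC1` is not yet measured. It differs from compound 3 by phenyl in place of ethynyl on a saturated chain carbon bound to an amine nitrogen in a ring, the same change at the same place. How the core of compound 3 differs from the core of compound 1 is not broken down here. A step of about an at least 1.2-fold lower number from compound 3 to compound 4 (0.09 log units; that floor lies within the scatter) is expected from compound 3 to compound 4, resting on an at least 3.0-fold lower number from compound 1 to compound 2 (0.47 log units; beyond the scatter) alone. Compound 3 starts at a limit, so the estimate is uncertain. Compound 4 is expected to land near 80000 nM, between 20000 nM and 300000 nM, and may again be reported only as a limit.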

Compound 4, half-maximal inhibitory concentration: > 100000 nM
Compound 4 ended at the assay's limit; the forecaster's own chance of this, stated with the estimate: 50%; middle value at least 1.2-fold (0.09 log units) from the limit.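

Compound 3 and compound 4 both end at a limit rather than a number, so no step between them can be read: the limit of > 100000 nM in this assay, at which 3 of the 4 values shown sit.

On these data alone, whether propargyl to benzyl changes anything on the core of compound 3, as it does on the core of compound 1, stays open.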